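The source may hold more compounds than are shown below. What is called first, only, known or untested is meant among the compounds shown, and "the series" means these compounds.

Working notes on the series. In a functional assay on A549 cells (Homo sapiens) for cytotoxicity, with a stated time of 48 h (a higher number here means a weaker inhibitor, a lower number a stronger inhibitor), compound 1 `Cc1ccc2c(=O)cc(/C=C/[S+](C)[O-])oc2c1` gives 2000 nM and compound 2 `CCCCCOc1ccc2oc(/C=C/[S+](C)[O-])cc(=O)c2c1` gives 1600 nM in the same read-out. Among the compounds with values here, compound 2 therefore stands within the scatter of the only other measured number, and the two cannot be ranked. Within the data shown here, no two measured compounds differ in one place, so the size of a single change is not yet known here.

Still to be measured is compound 3 `C[S+]([O-])/C=C/c1cc(=O)c2ccccc2o1`, which has hydrogen in place of pentyloxy on an aromatic carbon. The expectation rests on compound 1 at 2000 nM and compound 2 at 1600 nM lying within the scatter of each other while carrying different groups, and two compounds are thin support. No step beyond the scatter is expected in this assay, and the estimate of a 1.4-fold higher number from compound 2 to compound 3 (0.14 log units; within the scatter) stays a tentative one. For compound 3 the estimated value is 2200 nM with a range of 900 nM to 6000 nM expected for the measurement.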

Compound 3, half-maximal inhibitory concentration: 1900 nM
Estimate against measurement, compound 3: 1.2-fold (0.06 log units) above; low and high end bracket the measured number.
By their numbers in this assay, from the lowest: compounds 2, 3 and 1 (each within the scatter of the next).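

With compound 3 in hand, the series has its first comparisons that differ in one place, and in this assay the pentyloxy group proves dispensable at this position: hydrogen in place of pentyloxy on an aromatic carbon, on the six-membered aromatic ring of carbon only, gives a step within the scatter (a 1.2-fold higher number from compound 2 to compound 3 (0.07 log units; within the scatter)). Hydrogen in place of methyl on an aromatic carbon is likewise within the scatter (a 1.1-fold lower number from compound 1 to compound 3 (0.02 log units; within the scatter)), so neither group separates from hydrogen in this read-out, and compound 3 shows that the shared core without either group keeps a number within the scatter of both substituted compounds. No accompanying data bear on why these steps are so small.

On these data alone, whether any group on this aromatic carbon can give a step beyond the scatter stays open, for instance an amine, a carboxylic acid or a chain longer than pentyloxy. All the compounds shown also carry the same side chain on the shared core, so what that part contributes to the numbers in this assay remains unknown.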